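This account rests on a few compounds, and the source may have more. Where it says the series, first, only, none or still open, it means among the compounds named here.

In a functional assay on K562 cells (Homo sapiens), read by MTT assay, with a stated time of 72 h (on this read-out higher numbers stand for weaker inhibition and lower numbers for stronger inhibition), compound 2 (`Cc1ncnc2c1c(-c1ccoc1)cn2[C@@H]1O[C@H](CO)[C@@H](O)[C@H]1O`) is reported only as a limit, > 20000 nM. Compound 1 (`CNc1ncnc2c1c(-c1cccs1)cn2[C@@H]1O[C@H](CO)[C@@H](O)[C@H]1O`) is also reported only as a limit, > 20000 nM. Compound 3 (`Cc1ncnc2c1c(-c1cccs1)cn2[C@@H]1O[C@H](CO)[C@@H](O)[C@H]1O`) differs from compound 2 by one change, (thiophen-2-yl in place of furan-3-yl on an aromatic carbon), with thiophen-2-yl in place of furan-3-yl on an aromatic carbon. Compound 1 also bears thiophen-2-yl, and its limit of > 20000 nM calls for caution. In this assay, a modest move toward stronger inhibition is expected, an estimated at least 2.0-fold lower number from compound 2 to compound 3 (0.30 log units; that floor lies within the scatter), though another limit remains quite possible. Compound 3 is expected at 10000 nM, with an estimated range from 1500 nM to 30000 nM.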

Compound 3, half-maximal inhibitory concentration: > 20000 nM
Compound 3 ended at the assay's limit (the forecaster's own chance of this, stated with the estimate: 50%); middle value at least 2.0-fold (0.30 log units) away from the limit.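

In this assay no step can be read from compound 2 to compound 3 or from compound 1 to compound 3, because all three compounds stop at the same reported value: the limit of > 20000 nM in this assay, at which 3 of the 3 values shown sit. The compounds shown leave open whether either change alters inhibition at all.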